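The source may report more compounds than this note shows. Statements on the series, on what has been measured and on what is new or still open speak of the compounds shown alone.

Measured compounds:
compound 1 `COc1ccc(Nc2nc3ccccc3nc2S(=O)(=O)c2ccc(C)cc2)cc1`, compound 2 `COc1cc(Nc2nc3ccccc3nc2S(=O)(=O)c2ccc(C)cc2)cc(OC)c1`, compound 3 `COc1ccc(Nc2nc3ccccc3nc2S(=O)(=O)c2ccc(Br)cc2)cc1`.

In a functional assay on PC-3 cells (Homo sapiens) for cytotoxicity, read by MTT assay, with a stated time of 72 h (a higher number here means a weaker inhibitor, a lower number a stronger inhibitor), compound 1 gives only a limit, > 50000 nM (the limit of > 50000 nM in this assay, at which 1 of the 3 values shown sits). In this assay compound 2 gives 2940 nM and compound 3 gives 1110 nM. The change 3,5-dimethoxyphenyl in place of 4-methoxyphenyl on a nitrogen on an aromatic ring made the step of an at least 17-fold lower number from compound 1 to compound 2 (1.23 log units; beyond the scatter), and the change bromo in place of methyl on an aromatic carbon made the step of an at least 45-fold lower number from compound 1 to compound 3 (1.65 log units; beyond the scatter).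

Compound 4 `COc1cc(Nc2nc3ccccc3nc2S(=O)(=O)c2ccc(Br)cc2)cc(OC)c1` is not yet measured in this assay. It differs from compound 3 by 3,5-dimethoxyphenyl in place of 4-methoxyphenyl on a nitrogen on an aromatic ring, the same change that turned compound 1 into compound 2; the two cores differ only by bromo in place of methyl on an aromatic carbon. Since that change gave an at least 17-fold lower number from compound 1 to compound 2 (1.23 log units; beyond the scatter) on the core of compound 1, a lowering step is expected here too, though smaller because the earlier step began at a limit, the limit of > 50000 nM in this assay, at which 1 of the 3 values shown sits: compound 4 is expected to show a 2.2-fold lower number from compound 3 to compound 4 (0.35 log units; beyond the scatter). The estimate for compound 4 in this assay is 500 nM, within 150 nM and 1500 nM.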

Compound 4, half-maximal inhibitory concentration: 18200 nM
Compound 4: middle estimate off by 36-fold (1.56 log units), on the low side, outside the stated range (above it).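

In this assay, 3,5-dimethoxyphenyl in place of 4-methoxyphenyl gave a 16-fold higher number from compound 3 to compound 4 (1.21 log units; beyond the scatter), whereas the same change lowered the number on the core of compound 1, so it did not carry from one core to the other: the same change on two cores in this assay, an at least 17-fold lower number (1.23 log units; beyond the scatter) from compound 1 to compound 2 and a 16-fold higher number (1.21 log units; beyond the scatter) from compound 3 to compound 4, at least 270-fold (2.44 log units) apart, beyond the scatter of two such steps. Bromo in place of methyl also changed direction with the other group present, giving a 6.2-fold higher number from compound 2 to compound 4 (0.79 log units; beyond the scatter): the same change on two cores in this assay, an at least 45-fold lower number (1.65 log units; beyond the scatter) from compound 1 to compound 3 and a 6.2-fold higher number (0.79 log units; beyond the scatter) from compound 2 to compound 4, at least 270-fold (2.44 log units) apart, beyond the scatter of two such steps. Compound 1 gives only a limit, > 50000 nM, so these four compounds show that the two changes do not act independently, but not the exact size of the steps from compound 1 or the reason for the reversal: the limit of > 50000 nM in this assay, at which 1 of the 4 values shown sits.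

The compounds shown leave open whether the reversal persists with chloro or a nitrile in place of bromo. They also leave open what an amine in place of a methoxy group would do on either core.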